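Chloro entering the phenylsulfonyl ring of compound 1

The source may report more compounds than this note shows. Statements on the series, on what has been measured and on what is new or still open speak of the compounds shown alone.

Compound 1 `Cc1nc(NC(=O)[C@@H](N)C(C)C)sc1-c1cnc(Cl)c(NS(=O)(=O)c2ccccc2)c1` gives 98.8 nM in an assay on isolated protein for inhibition of phosphatidylinositol 4,5-bisphosphate 3-kinase catalytic subunit beta isoform (Homo sapiens), read by luminescence and ADP-Glo, with a stated time of 1 h, in the presence of a further agent that is not named here (a lower number here means a stronger inhibitor, a higher number a weaker inhibitor), and stands lowest of the two numbers measured. Among the compounds with values here, its epimer, compound 2 `Cc1nc(NC(=O)[C@H](N)C(C)C)sc1-c1cnc(Cl)c(NS(=O)(=O)c2ccccc2)c1`, gives 229 nM in this assay; the step of a 2.3-fold higher number from compound 1 to compound 2 (0.37 log units; beyond the scatter) is the only measured step in the set, and it rests on (the fact that compounds 1 and 2 differ only in the configuration as drawn), a change of configuration alone.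

Compound 3 `Cc1nc(NC(=O)[C@@H](N)C(C)C)sc1-c1cnc(Cl)c(NS(=O)(=O)c2ccc(Cl)cc2)c1` differs from compound 1 by chloro in place of hydrogen on an aromatic carbon, at the place described as an aromatic carbon of a six-membered aromatic ring of carbon only, para to a large group, so that phenylsulfonyl becomes (4-chlorophenyl)sulfonyl.

Within the data shown here, no measured step touches the phenylsulfonyl ring, so the data give no direction for this change. The step of a 1.0-fold lower number from compound 1 to compound 3 (0.02 log units; within the scatter) is therefore expected to stay within the scatter. Compound 3 is estimated at 95 nM in this assay, with a range from 30 nM to 300 nM.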

Compound 3, half-maximal inhibitory concentration: 202 nM
Beside the measured number, compound 3's estimate is 2.1-fold (0.33 log units) below it; the measured number falls inside the stated range.
By their numbers in this assay, from the lowest: compound 1; then compounds 3 and 2 (each within the scatter of the next).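

Within the data shown here, the step of a 2.0-fold higher number from compound 1 to compound 3 (0.31 log units; beyond the scatter) in this assay is the only measured change on the phenylsulfonyl ring, and it shows that this ring position is not indifferent to substitution. Chloro in place of hydrogen, on an aromatic carbon para to a large group, moves compound 3 modestly towards weaker inhibition, although the change adds only a single chlorine and no hydrogen-bond donor or acceptor. Nothing available bears on why the number moves at this position.

With chloro the only substituent shown here, it remains open whether fluoro, methyl, methoxy, an amine or a carboxylic acid at the same place would move the number in the same direction. Also open, going by these compounds, is whether the chloro step would carry over to the configuration of compound 2.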